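Swapping the Sulfonyl Aryl Group of Compound 1

A few compounds are considered here, and "the series" means these few. Any claim that something is new, unique, unknown or untested is made for them only; others in the source may bear on it.

Measured compounds:
compound 1 `CC1CCN(c2c(S(=O)(=O)c3ccc(Cl)cc3)cnc3cc(Cl)ccc23)CC1` — 91%
compound 2 `CC1CCN(c2c(S(=O)(=O)c3ccc(Cl)cc3)cnc3cc(F)ccc23)CC1` — 90%
compound 3 `COc1ccc(S(=O)(=O)c2cnc3ccc(C)cc3c2N2CCC(C)CC2)cc1` — 62%

In an assay on isolated protein for displacement of a labelled ligand from metabotropic glutamate receptor 5 (Homo sapiens), with a stated time of 60 min, tested at 1 uM (a higher number here means more inhibition at the concentration tested (going by the name of the read-out), a lower number less inhibition), compound 1 gives 91%, the highest of the three numbers. Compound 2 gives 90%, and a number 1 percentage points lower from compound 1 to compound 2 (within the scatter). Compound 3 gives 62%, the furthest from compound 1.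

Compound 4 `COc1cccc(S(=O)(=O)c2cnc3cc(Cl)ccc3c2N2CCC(C)CC2)c1` differs from compound 1 in one place: 3-methoxyphenyl in place of 4-chlorophenyl on a sulfonyl sulfur. Going by the values given here, the only measured step, from compound 1 to compound 2, changes a different part of the molecule and stays within the scatter, so it says nothing about this swap. Among the compounds with values here, compound 3 is the only measured compound with a methoxyphenyl on the sulfonyl sulfur, yet it also differs from compound 1 in a second place, so its lower value is a loose hint at most. A moderate loss is therefore expected, a number 16 percentage points lower from compound 1 to compound 4 (beyond the scatter). Compound 4 is estimated at 75%, ranging from 50% to 92%.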

Compound 4, a percentage reported as inhibition, at one concentration (the size of the read-out at that concentration, not a potency): 93%
The estimate for compound 4 lay 18 percentage points below the measured number, and the stated range ends below it.
By their numbers in this assay, from the lowest: compound 3; then compounds 2, 1 and 4 (each within the scatter of the next).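

Putting 3-methoxyphenyl in place of 4-chlorophenyl on a sulfonyl sulfur gives a number 2 percentage points higher from compound 1 to compound 4 (within the scatter) in this assay. This position therefore accepts a different aryl group with no visible change in inhibition, and the chlorine of compound 1 is not required for this read-out at the concentration tested. No measured evidence explains this level inhibition.

From the compounds shown here alone, a single concentration gives no potency, so any difference between these two compounds at lower concentrations stays unknown. Also open, going by these compounds, is whether an amine or a carboxylic acid on this phenyl ring, or a simple ethyl chain replacing the ring, would hold the inhibition.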